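From compound 2 to compound 3: replacing 2,4-dichlorophenyl

The compounds below may be only part of what the source reports. "The series", "measured", "known", "first", "only" and "open" are said of these compounds alone.

In a functional assay on SMMC-7721 cells (Homo sapiens) for cytotoxicity, read by MTT assay, with a stated time of 72 h (on this read-out higher numbers stand for weaker inhibition and lower numbers for stronger inhibition), compound 1 `COc1ccccc1C=C1C(=O)N(c2ccc(Cl)cc2)N(c2ccc(Cl)cc2)C1=O` gives 25800 nM as a measured number. Compound 2 `O=C1C(=Cc2ccc(Cl)cc2Cl)C(=O)N(c2ccc(Cl)cc2)N1c1ccc(Cl)cc1` stands at > 128000 nM and this is a limit of the assay, not a number. Compound 3 `O=C1C(=C/C=C/c2ccccc2)C(=O)N(c2ccc(Cl)cc2)N1c1ccc(Cl)cc1` differs from it by 2-phenylethenyl in place of 2,4-dichlorophenyl on a double-bonded chain carbon bound to a double-bonded ring carbon and so loses the 2,4-dichlorophenyl. Within the data shown here, the only measured step at this place is an at least 4.9-fold higher number from compound 1 to compound 2 (0.69 log units; beyond the scatter) and it points to that group as the one to leave. A lower number in this assay is therefore expected, towards compound 1 at 25800 nM in this series. The expected change is an at least 2.8-fold lower number from compound 2 to compound 3 (0.45 log units; beyond the scatter) in size. For compound 3 the estimated value is 45000 nM with an expected range of 12000 nM to 128000 nM in this read-out.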

Compound 3, half-maximal inhibitory concentration: 10100 nM
Compound 3: middle estimate off by 4.5-fold (0.65 log units), on the high side; the measured number lies below the stated range.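

In this assay, 2-phenylethenyl on a double-bonded chain carbon bound to a double-bonded ring carbon goes beyond 2-methoxyphenyl at this place, giving a 2.6-fold lower number from compound 1 to compound 3 (0.41 log units; beyond the scatter). Against 2,4-dichlorophenyl, the same group gives an at least 12-fold lower number from compound 2 to compound 3 (1.10 log units; beyond the scatter). Compound 2 stands at a limit of the assay and not at a number, so this step has only a lower bound: the limit of > 128000 nM in this assay, at which 1 of the 3 values shown sits.

Still open, going by these compounds, is whether the double bond of 2-phenylethenyl matters, which a saturated 2-phenylethyl group would test. Also open, on these data alone, is how a dimethylamino group on its phenyl ring would read.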